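Cytotoxicity notes on a bromo-to-methyl pair

A few compounds are considered here, and "the series" means these few. Any claim that something is new, unique, unknown or untested is made for them only; others in the source may bear on it.

Measured so far in Vero cells:
compound 1 `Clc1ccc2c(NCCCNc3nccc(Nc4ccc(Br)cc4)n3)ccnc2c1` gives 11200 nM
compound 2 `Cc1ccc(Nc2ccnc(NCCCNc3ccnc4cc(Cl)ccc34)n2)cc1` gives 18500 nM
compound 3 `Clc1ccc2c(NCCCCNc3nccc(Nc4ccc(Br)cc4)n3)ccnc2c1` gives 10000 nM

All three numbers come from an ADME assay on Vero cells (Chlorocebus sabaeus) for cytotoxicity, read by neutral red uptake, with a stated time of 72 h; a higher number here means a weaker inhibitor, a lower number a stronger inhibitor. Compound 1 and compound 2 differ in one place: methyl in place of bromo on an aromatic carbon. That change produced a 1.7-fold higher number from compound 1 to compound 2 (0.22 log units; within the scatter). Compound 3 carries the same bromophenyl end as compound 1 on a different core; the difference between the two cores is not broken down here. The values of compound 3 and compound 1 sit within the scatter of each other, as do those of compound 3 and compound 2.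

Compound 4 `Cc1ccc(Nc2ccnc(NCCCCNc3ccnc4cc(Cl)ccc34)n2)cc1` has not yet been run. It stands to compound 3 as compound 2 stands to compound 1: methyl in place of bromo on an aromatic carbon. The place lines of the two changes read the same word for word, so this is the same change made a second time, now on the core of compound 3.

For the measured compounds named here, the only guide to its size is the step already seen between compound 1 and compound 2, which stayed within the scatter. For compound 4 the expectation is a step of similar size, a 1.7-fold higher number from compound 3 to compound 4 (0.23 log units; within the scatter), resting on the pair compound 1 to compound 2 and on the value of compound 3, 10000 nM. Compound 4 is therefore estimated at 17000 nM, with a range from 8000 nM to 35000 nM.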

Compound 4, half-maximal inhibitory concentration: 19300 nM
Beside the measured number, compound 4's estimate is 1.1-fold (0.06 log units) below it; low and high end bracket the measured number.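

In this assay, methyl in place of bromo on the core of compound 3 gives a 1.9-fold higher number from compound 3 to compound 4 (0.29 log units; within the scatter) and, set beside the earlier case on the core of compound 1, the two steps agree: the same change on two cores in this assay, a 1.7-fold higher number (0.22 log units; within the scatter) from compound 1 to compound 2 and a 1.9-fold higher number (0.29 log units; within the scatter) from compound 3 to compound 4, 1.2-fold (0.07 log units) apart, within the scatter of two such steps

For these two pairs, then, the change from 4-bromophenyl to 4-methylphenyl carries from one core to the other with a step of matching size, and the core makes no difference that can be read from these numbers. This does not show that the change itself has a real effect on the read-out, as each step taken alone stays within the scatter, and agreement between two such small steps may reflect little more than two pairs with no real difference; nor does it say anything about cores other than these two.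

What the compounds shown leave open is whether a group of another kind at the same place, such as a nitrile, a methoxy group or a carboxylic acid, would move the number beyond the scatter. Also open, going by these compounds, is whether the same agreement would hold on a core with a longer chain, where only further matched pairs could tell.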